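Naphthyl pyridine series: ester and amide side chains

The source may hold more compounds than are shown below. What is called first, only, known or untested is meant among the compounds shown, and "the series" means these compounds.

Measured so far:
compound 1, `COC(=O)/C=C/c1ccncc1-c1ccc2ccccc2c1` — 40.6 nM in an assay on a protein complex for inhibition of CDK8/Cyclin C (Homo sapiens), with a stated time of 1 h; a lower number here means a stronger inhibitor, a higher number a weaker inhibitor
compound 2, `CNC(=O)COc1ccncc1-c1ccc2ccccc2c1` — "not determined" (no result reported)

Compound 2 stands nowhere on the numbers: in this assay compound 2 gives "not determined" (no result reported), so there is no half-maximal inhibitory concentration to place it against compound 1. The only figure in the series is that of compound 1, which in this assay gives 40.6 nM.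

Compound 3, `COC(=O)CCc1ccncc1-c1ccc2ccccc2c1`, is the next compound for this assay. Relative to compound 2 the change is 2-(methoxycarbonyl)ethyl in place of (methylcarbamoyl)methoxy on an aromatic carbon. For the measured compounds named here, with no number for compound 2, no step from compound 2 to compound 3 can be sized; whatever the difference, it cannot be set against the scatter of this assay. Going by the values given here, the only anchor is compound 1, whose side chain shares the methoxycarbonyl end with compound 3.

Compound 3 is expected to give about 90 nM in this assay, within a range of 25 nM to 350 nM.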

Compound 3, half-maximal inhibitory concentration: 259 nM
The estimate for compound 3 lay 2.9-fold (0.46 log units) below the measured number; the range from low to high includes it.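

In this assay this position, on an aromatic carbon opposite the ring nitrogen, now has its first measured step: with the methoxycarbonyl end kept, 2-(methoxycarbonyl)ethyl in place of 2-(methoxycarbonyl)ethenyl gives a 6.4-fold higher number from compound 1 to compound 3 (0.80 log units; beyond the scatter). Within this pair, then, the link carrying the ester counts as well as the ester end, and the lower number goes with the double bond of compound 1. Nothing measured here bears on why the number shifts.

For the compounds shown here, compound 2 has no number, so no step to or from it can be read and its amide side chain stays unplaced against either ester. Going by these compounds, whether a carboxylic acid or a methyl amide on the ethenyl chain, or a longer chain, would keep the number of compound 1 remains open.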